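A few compounds are considered here, and "the series" means these few. Any claim that something is new, unique, unknown or untested is made for them only; others in the source may bear on it.

Three compounds share one core and differ only in a single group on one six-membered aromatic ring. Compound 1 `Cc1cc(-c2sc(Cc3cccc(C(F)(F)F)c3)nc2C)ccc1C(N)=O` carries a methyl there, compound 2 `COc1cc(-c2sc(Cc3cccc(C(F)(F)F)c3)nc2C)ccc1C(N)=O` a methoxy, and compound 3 `Cc1nc(Cc2cccc(C(F)(F)F)c2)sc1-c1ccc(C(N)=O)c(C(F)(F)F)c1` a trifluoromethyl. In a functional assay on cells for agonist activity at G-protein coupled receptor 52 (Homo sapiens), read by AlphaScreen and cAMP accumulation, with a stated time of 30 min (on this read-out lower numbers stand for an effect already at smaller amounts and higher numbers for an effect only at larger amounts of compound), compound 1 gives 73 nM, compound 2 gives 170 nM, and compound 3 gives 110 nM. The step from compound 1 to compound 2 is a 2.3-fold higher number from compound 1 to compound 2 (0.37 log units; beyond the scatter). The step of a 1.5-fold higher number from compound 3 to compound 2 (0.19 log units; within the scatter) and the step of a 1.5-fold higher number from compound 1 to compound 3 (0.18 log units; within the scatter) both stay within the scatter, so compounds 1 and 3 cannot be told apart on this read-out.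

Compound 4 `COc1cccc(Cc2nc(C)c(-c3ccc(C(N)=O)c(C)c3)s2)c1` has not yet been measured in this assay. Relative to compound 1 it differs as follows: methoxy in place of trifluoromethyl on an aromatic carbon. The same kind of change is already seen between two measured compounds, from compound 3 to compound 2: methoxy in place of trifluoromethyl on an aromatic carbon. The surroundings are not the same, though: in the measured pair the changed carbon is ortho to a carbamoyl group and meta to a large group, whereas in compound 4 it is meta to a large group only. The two starting points also differ in their cores: methyl in place of trifluoromethyl on an aromatic carbon.

The expectation for compound 4 rests on the measured pair, where the step of a 1.5-fold higher number from compound 3 to compound 2 (0.19 log units; within the scatter) stayed within the scatter. The expected step is of a similarly small size, a 1.5-fold higher number from compound 1 to compound 4 (0.18 log units; within the scatter). Compound 4 is thus estimated to give 110 nM, most likely between 40 nM and 300 nM.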

Compound 4, half-maximal effective concentration: 160 nM
The estimate for compound 4 lay 1.5-fold (0.16 log units) below the measured number; the range from low to high includes it.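

In this assay, putting methoxy in place of trifluoromethyl on the ring of compound 1 gives a 2.2-fold higher number from compound 1 to compound 4 (0.34 log units; beyond the scatter), a modest step but one that can be read as real. Set beside the same change made at a different place on a different core, the two steps do not differ by more than repeated measurements of this kind would allow: the same change on two cores in this assay, a 1.5-fold higher number (0.19 log units; within the scatter) from compound 3 to compound 2 and a 2.2-fold higher number (0.34 log units; beyond the scatter) from compound 1 to compound 4, 1.4-fold (0.15 log units) apart, within the scatter of two such steps So, as far as these two pairs go, the change carries over without any detectable difference in size, but this is not proof that its effect is the same on both cores, since only one of the two steps lies beyond the scatter, the surroundings of the changed carbon differ, and two pairs cannot establish a rule for the series.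

The compounds shown leave open whether other groups at the place changed in compound 4, such as a chlorine, a nitrile or an amine, would give lower or higher numbers than trifluoromethyl does. They also leave open what happens when methoxy stands on both aromatic rings at once, a combination that would test whether the two changes simply add up.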